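The compounds below may be only part of what the source reports. "The series", "measured", "known", "first", "only" and "open" are said of these compounds alone.

Measured so far in an ADME assay on cells (Hepatocyte, Homo sapiens) for metabolic stability, with a stated time of 30 min; a higher number here means that more of the compound is left, a lower number that less of the compound is left:
Compound 1 `O=C(OC1CCC(CN2CCN(c3cc(=O)c4cc(C(F)(F)F)cc([N+](=O)[O-])c4s3)CC2)CC1)c1ccccc1`: 56.4%
Compound 2 `O=C(NC1CCC(CN2CCN(c3cc(=O)c4cc(C(F)(F)F)cc([N+](=O)[O-])c4s3)CC2)CC1)c1ccccc1`: 92.9%
Compound 3 `O=C(OC1CCC(CN2CCN(c3cc(=O)c4cc(C(F)(F)F)cc([N+](=O)[O-])c4s3)CC2)CC1)c1ccco1`: 1%

Of these three, compound 3 stands lowest, at 1%, and its distance from each of the other two lies beyond the scatter. The next compound is compound 4 `CC(=O)NC1CCC(CN2CCN(c3cc(=O)c4cc(C(F)(F)F)cc([N+](=O)[O-])c4s3)CC2)CC1`, which has acetamido in place of ((furan-2-yl)carbonyl)oxy on a saturated ring carbon.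

For the measured compounds named here, three measured steps bear on this change. With benzamido in place of benzoyloxy on a saturated ring carbon, the record shows a number 36.5 percentage points higher from compound 1 to compound 2 (beyond the scatter). With furan-2-yl in place of phenyl on a carbonyl carbon, it shows a number 55.4 percentage points lower from compound 1 to compound 3 (beyond the scatter). Going by the values given here, the closest precedent is the step with ((furan-2-yl)carbonyl)oxy in place of benzamido, a number 91.9 percentage points lower from compound 2 to compound 3 (beyond the scatter), which runs opposite to the change now at hand. Among the compounds with values here, no measured step compares acetamido with benzamido directly, so that part remains open.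

The expectation rests mainly on compound 2, which carries benzamido and reads 92.9%. A large upward move in this assay is expected, an estimated a number 87 percentage points higher from compound 3 to compound 4 (beyond the scatter). For compound 4 the expected value is 88%, with an estimated range from 68% to 100%.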

Compound 4, percent of the compound remaining: 86.8%
The estimate for compound 4 lay 1.2 percentage points above the measured number; the range from low to high includes it.
By their numbers in this assay, from the lowest: compound 3; then compound 1; then compounds 4 and 2 (each within the scatter of the next).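

In this assay the change to acetamido on a saturated ring carbon gives a number 85.8 percentage points higher from compound 3 to compound 4 (beyond the scatter) and, set against benzoyloxy, a number 30.4 percentage points higher from compound 1 to compound 4 (beyond the scatter), so a high reading at this position does not depend on a phenyl group on the carbonyl carbon. That point is sharpened by methyl in place of phenyl on the carbonyl carbon, which gives a number 6.1 percentage points lower from compound 2 to compound 4 (within the scatter): among the compounds with an amide nitrogen on the ring carbon, a group with no ring serves as well as the phenyl, whereas furan-2-yl in place of phenyl had marked a large fall among those with an oxygen there. Nothing given here accounts for these differences.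

As far as these compounds go, whether furan-2-yl on the carbonyl carbon of an amide would read like compound 2 or like compound 3 stays open, as does the reading of acetoxy on the same ring carbon. Also open, from the compounds shown here alone, is how a longer chain on the carbonyl carbon, or a free amine or a carboxylic acid on that ring carbon, would compare with acetamido.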